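The source may report more compounds than this note shows. Statements on the series, on what has been measured and on what is new or still open speak of the compounds shown alone.

In a functional assay on MDA-MB-231 cells (Homo sapiens), read by wound healing assay, with a stated time of 24 h; on this read-out lower numbers stand for stronger inhibition and higher numbers for weaker inhibition:
- compound 1 `CC(C)=CCC[C@H](C)c1ccc(C)c2c1OCN(CC1CCNCC1)C2`: 8100 nM
- compound 2 `CC(C)=CCC[C@H](C)c1ccc(C)c2c1OCN(CCCCCO)C2`: 10000 nM

Going by the values given here, compound 2 stands level with compound 1, the only other measured compound: the single measured step is a 1.2-fold higher number from compound 1 to compound 2 (0.09 log units; within the scatter). Compound 3 `CC(C)=CCC[C@H](C)c1ccc(C)c2c1OCN(CCCCC(=O)O)C2` carries carboxy in place of hydroxymethyl on a saturated chain carbon, four bonds along the chain from an amine nitrogen in a ring. Among the compounds with values here, no measured compound carries carboxy, so that one step bears only indirectly, as a change in the same substituent of the shared core. The expected step is a 1.1-fold higher number from compound 2 to compound 3 (0.04 log units; within the scatter), with nothing expected beyond the scatter. For compound 3 the estimate is 11000 nM, with an expected range of 4000 nM to 30000 nM.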

Compound 3, half-maximal inhibitory concentration: 29900 nM
The estimate for compound 3 lay 2.7-fold (0.43 log units) below the measured number, and the stated range covers the measured number.
By their numbers in this assay, from the lowest: compounds 1 and 2 (each within the scatter of the next); then compound 3.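

In this assay, going by these compounds alone, the first change beyond the scatter appears: carboxy in place of hydroxymethyl on a saturated chain carbon, four bonds along the chain from an amine nitrogen in a ring, gives a 3.0-fold higher number from compound 2 to compound 3 (0.48 log units; beyond the scatter). On a saturated chain carbon bound to an amine nitrogen in a ring, 3-carboxypropyl also separates from piperidin-4-yl with a 3.7-fold higher number from compound 1 to compound 3 (0.57 log units; beyond the scatter), which 4-hydroxybutyl did not do. Nothing at hand accounts for this step. Still open, from the compounds shown here alone, is whether a methyl ester or a primary amide at this place follows carboxy or hydroxymethyl, and whether a longer chain carrying carboxy moves the number further.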